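Trifluoromethyl in place of chloro: expected effect on compound 3

The source may hold more compounds than are shown below. What is called first, only, known or untested is meant among the compounds shown, and "the series" means these compounds.

The two measured compounds share one core and differ at a single aromatic carbon. Compound 1 `CC(C)(C)c1ccc(-n2nc(-c3ccc(C(F)(F)F)cc3O)nc2-c2ccccc2O)cc1` gives 67.3% in a functional assay on PC-12 cells (Rattus norvegicus) for cytotoxicity, read by MTT assay, with stated times of 2 h and 24 h, tested at 1 uM; a lower number here means a weaker effect, a higher number a stronger effect of the compound at the concentration tested. Compound 2 `Oc1cc(C(F)(F)F)ccc1-c1nc(-c2ccccc2O)n(-c2ccc(Cl)cc2)n1` gives 68% in this assay. Going by the values given here, the only measured step, a number 0.7 percentage points higher from compound 1 to compound 2 (within the scatter), puts chloro in place of tert-butyl on that aromatic carbon. Compound 2 therefore sits at the top of the two numbers shown, but compound 1 lies within the scatter of it, so the two cannot be told apart on these data.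

Compound 3 `Oc1cc(C(F)(F)F)ccc1-c1nc(-c2ccccc2O)n(-c2ccc(C(F)(F)F)cc2)n1` is not yet measured. Relative to compound 2 the change is trifluoromethyl in place of chloro on an aromatic carbon. Among the compounds with values here, the single step that bears on it, a number 0.7 percentage points higher from compound 1 to compound 2 (within the scatter), exchanged two quite different groups at the same aromatic carbon and left the read-out essentially unchanged. Trifluoromethyl is a third group at that carbon, and nothing in the series suggests that this position moves the response. The expected step of a number 1 percentage points lower from compound 2 to compound 3 (within the scatter) is therefore none beyond the scatter. Compound 3 is estimated at 67% in this assay, with a likely range from 56% to 78%.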

Compound 3, a percentage reported as activity, at one concentration (the size of the read-out at that concentration, not a potency): 70.7%
Compound 3: middle estimate off by 3.7 percentage points, on the low side, and the stated range covers the measured number.
By their numbers in this assay, from the lowest: compounds 1, 2 and 3 (each within the scatter of the next).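

In this assay, a third group on this aromatic carbon still gives no step beyond the scatter: a number 2.7 percentage points higher from compound 2 to compound 3 (within the scatter) for the change from 4-chlorophenyl to 4-(trifluoromethyl)phenyl, and a number 3.4 percentage points higher from compound 1 to compound 3 (within the scatter) for trifluoromethyl in place of tert-butyl. The earlier compounds shown here offered a single exchange at this carbon, whereas tert-butyl, chloro and trifluoromethyl now form three pairs, none of which can be told apart in this read-out, and no compound among the three goes against this flat pattern. No measurement shown bears on why the read-out stays level across these groups.

The compounds shown leave open whether an amine, a carboxylic acid or a longer alkyl chain on this aromatic carbon would also leave the read-out level, as the three groups in hand all lack hydrogen-bond donors and acceptors by the count for chloro and trifluoromethyl. They also leave open what replacing either hydroxyl group or the second trifluoromethyl on the shared core would do, as these stay fixed in compounds 1, 2 and 3.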